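Indazole urea series: chlorophenyl position change

This account rests on a few compounds, and the source may have more. Where it says the series, first, only, none or still open, it means among the compounds named here.

Measured so far in an assay on CHO-K1 cells for antagonist activity at transient receptor potential cation channel subfamily V member 1 (Homo sapiens), read by FLIPR and calcium flux, with a stated time of 6 min; on this read-out higher numbers stand for weaker inhibition and lower numbers for stronger inhibition:
compound 1 `Cn1ncc2cc(NC(=O)NCc3cc(C(F)(F)F)nn3-c3cccc(Cl)c3)ccc21`: 61 nM
compound 2 `O=C(NCc1cc(C(F)(F)F)nn1-c1cccc(Cl)c1)Nc1cccc2[nH]ncc12`: 0.9 nM

Among the compounds with values here, compound 2 has the lowest of the two numbers in this assay; the only step measured so far, a 68-fold lower number from compound 1 to compound 2 (1.83 log units; beyond the scatter), separates it from compound 1 and lies beyond the scatter.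

Compound 3 `O=C(NCc1cc(C(F)(F)F)nn1-c1ccc(Cl)cc1)Nc1cccc2[nH]ncc12` has not yet been measured in this assay. Against compound 2 the difference is 4-chlorophenyl in place of 3-chlorophenyl on an aromatic nitrogen.

Within the data shown here, no measured step touches this position: the only step on record, a 68-fold lower number from compound 1 to compound 2 (1.83 log units; beyond the scatter), concerns the group on the amide-type nitrogen and leaves the chlorophenyl on the aromatic nitrogen untouched. The expectation for compound 3 therefore rests on no measured comparison and is given wide bounds. Moving the chlorine within the same ring, with the same atoms joined differently, is expected to change the number by a 3.3-fold higher number from compound 2 to compound 3 (0.52 log units; beyond the scatter), a step that may sit within the scatter or a little beyond it toward weaker inhibition. For compound 3 the estimate in this assay is 3 nM, with a range of 0.6 nM to 15 nM.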

Compound 3, inhibition constant: 2.5 nM
Beside the measured number, compound 3's estimate is 1.2-fold (0.08 log units) above it; low and high end bracket the measured number.
By their numbers in this assay, from the lowest: compound 2; then compound 3; then compound 1.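

In this assay, the chlorophenyl on the aromatic nitrogen now has its first measured step: a 2.8-fold higher number from compound 2 to compound 3 (0.44 log units; beyond the scatter) shows that the number responds to where the chlorine sits on this ring, even though 3-chlorophenyl and 4-chlorophenyl have the same heavy atoms and the same aromatic ring. This modest step lies beyond the scatter but is much smaller than a 68-fold lower number from compound 1 to compound 2 (1.83 log units; beyond the scatter) on the amide-type nitrogen, and compound 3 still gives a single-digit nanomolar number with the chlorine moved. No measured evidence bears on why the two chlorine placements give different numbers.

The compounds shown do not tell how this ring would read with a methoxy group, a nitrile or a fluorine in place of the chlorine, or as a plain phenyl with no chlorine at all, so the part played by the chlorine itself remains open. Also open, as far as these compounds go, is whether the same shift from 3-chlorophenyl to 4-chlorophenyl would be seen with the group carried by compound 1 on the amide-type nitrogen, since both members of this pair carry the group found in compound 2.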